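This account rests on a few compounds, and the source may have more. Where it says the series, first, only, none or still open, it means among the compounds named here.

Compound 1 `c1ccc(CNc2nnc(-c3nc4ccncc4s3)o2)cc1` gives 66 mL.min-1.g-1
Compound 2 `Fc1cccc(CNc2nnc(-c3c[nH]c4ncccc34)o2)c1` gives 71 mL.min-1.g-1

In an ADME assay (liver) for metabolic stability, with Liver microsome (Rattus norvegicus) as the target, using microsomes (on this read-out higher numbers stand for fast clearance and lower numbers for slow clearance), compound 2 gives 71 mL.min-1.g-1 and stands within the scatter of compound 1 at 66 mL.min-1.g-1. Compound 3 `c1cncc(CNc2nnc(-c3c[nH]c4ncccc34)o2)c1` has pyridin-3-yl in place of 3-fluorophenyl on a saturated chain carbon bound to a nitrogen on an aromatic ring and has not yet been measured. Among the measured compounds shown here, no measured pair shows this change, so the expectation rests on the structural change alone. In this assay a small move toward slower clearance is expected, estimated as a 1.9-fold lower number from compound 2 to compound 3 (0.27 log units; within the scatter) and not clearly beyond the scatter. The estimated value for compound 3 is 38 mL.min-1.g-1 with an expected range from 16 mL.min-1.g-1 to 75 mL.min-1.g-1 in this read-out.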

Compound 3, intrinsic clearance in microsomes: 30 mL.min-1.g-1
Estimate against measurement, compound 3: 1.3-fold (0.10 log units) above; low and high end bracket the measured number.
By their numbers in this assay, from the lowest: compound 3; then compounds 1 and 2 (each within the scatter of the next).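

In this assay, pyridin-3-yl in place of 3-fluorophenyl on a saturated chain carbon bound to a nitrogen on an aromatic ring gives a 2.4-fold lower number from compound 2 to compound 3 (0.37 log units; beyond the scatter). This shows that the read-out responds to a change at this place, which compound 1 and compound 2, differing in more than one place, could not show. Nothing measured here accounts for the step. The compounds shown leave open how pyridin-4-yl or a longer chain would read at this place. They also leave open whether the same change holds on the core of compound 1.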